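The source may report more compounds than this note shows. Statements on the series, on what has been measured and on what is new or still open speak of the compounds shown alone.

In an assay for binding affinity to dual specificity mitogen-activated protein kinase kinase 4 (Homo sapiens), read by KINOMEscan, tested at 100 nM (a lower number here means a stronger effect, a higher number a weaker effect of the compound at the concentration tested), the measured compounds stand as follows:

compound 1 `CCCS(=O)(=O)Nc1ccc(F)c(C(=O)c2n[nH]c3ncc(-c4ccc(C)cc4)cc23)c1F`: 5.4%
compound 2 `CCCS(=O)(=O)Nc1ccc(F)c(C(=O)c2n[nH]c3ncc(-c4ccc(Cl)cc4Cl)cc23)c1F`: 22%
compound 3 `CCCS(=O)(=O)Nc1ccc(F)c(C(=O)c2n[nH]c3ncc(-c4ccc(F)cc4C)cc23)c1F`: 14%

Compound 3 holds the second highest of the three numbers. Its nearest neighbour is compound 2, a number 8 percentage points lower from compound 2 to compound 3 (within the scatter); the furthest is compound 1, a number 8.6 percentage points higher from compound 1 to compound 3 (within the scatter). Among the compounds with values here, only one step in the set lies beyond the scatter, a number 16.6 percentage points higher from compound 1 to compound 2 (beyond the scatter), and even that one is modest.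

Compound 4 `CCCS(=O)(=O)Nc1ccc(F)c(C(=O)c2n[nH]c3ncc(-c4cccc(C(F)(F)F)c4)cc23)c1F` carries a third variant of the pendant aryl group: 3-(trifluoromethyl)phenyl in place of 4-fluoro-2-methylphenyl on an aromatic carbon

Within the data shown here, the steps that bear on this change are the three aryl swaps already recorded. Among the measured compounds shown here, of these, two stay within the scatter and one is modest, so the series so far shows the pendant aryl shifting the read-out in this assay only by small amounts, and no measured step reaches the unsubstituted-to-trifluoromethyl pattern directly. For compound 4 a step of roughly a number 4 percentage points higher from compound 3 to compound 4 (within the scatter) is therefore expected, most likely within the scatter, with the upper side slightly more probable given that compound 1 gives 5.4% and compound 2 gives 22%, bracketing compound 3 from both sides. The estimate for compound 4 in this assay is 18%, expected to fall between 5% and 40%.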

Compound 4, a percentage reported as activity, at one concentration (the size of the read-out at that concentration, not a potency): 57%
Beside the measured number, compound 4's estimate is 39 percentage points below it; measured number above the stated range.
By their numbers in this assay, from the lowest: compounds 1, 3 and 2 (each within the scatter of the next, the first and the last beyond it); then compound 4.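

Swapping the pendant aryl group at this position is not always a small change in this assay: 3-(trifluoromethyl)phenyl gives a number 43 percentage points higher from compound 3 to compound 4 (beyond the scatter), a number 35 percentage points higher from compound 2 to compound 4 (beyond the scatter) and a number 51.6 percentage points higher from compound 1 to compound 4 (beyond the scatter), so compound 4 has the weakest effect of the four, with all three steps large and beyond the scatter. The earlier aryl swaps gave at most a modest step, so this position can carry a much larger change in the read-out than compounds 1, 2 and 3 alone showed, and 3-(trifluoromethyl)phenyl is also the only one of the four aryl groups named without a substituent at the 4-position. No measured evidence bears on the size of these steps.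

The compounds shown leave open whether the loss follows the trifluoromethyl group itself or the absence of a 4-substituent, since both differ at once in every step to compound 4. A 4-(trifluoromethyl)phenyl group and a 3-methylphenyl group on the same core would separate the two, and a 3-aminophenyl group would show whether another 3-substituent behaves in the same way.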